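Replacing the cyclohexyl group of compound 1

The source may hold more compounds than are shown below. What is called first, only, known or untested is meant among the compounds shown, and "the series" means these compounds.

Measured so far in an ADME assay on MT4 cells (Homo sapiens) for cytotoxicity, with a stated time of 5 days (on this read-out higher numbers stand for lower toxicity in this test and lower numbers for higher toxicity in this test), with these results
- compound 1 `CC(C)N(C(=O)C1CCCCC1)c1cc(C#CC(C)(C)C)sc1C(=O)O` with > 20000 nM
- compound 2 `CC(C)(C)C#Cc1cc(N(C(=O)[C@H]2CC[C@H](C)CC2)[C@H]2CC[C@H](OC3CCOC3)CC2)c(C(=O)O)s1` with > 20000 nM

In this assay compound 1 stands at > 20000 nM as a limit of the assay and not a number. Compound 2 gives > 20000 nM as a limit too. The data so far show the limit of > 20000 nM in this assay, at which 2 of the 2 values shown sit, and no actual number.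

Compound 3 `CC(C)N(C(=O)[C@H]1[C@@H]2CCCC[C@@H]21)c1cc(C#CC(C)(C)C)sc1C(=O)O` differs from compound 1 in one place, as follows a group of 7 heavy atoms (7 carbon; one three-membered non-aromatic ring of carbon only, one six-membered non-aromatic ring of carbon only) in place of a group of 6 heavy atoms (6 carbon; one six-membered non-aromatic ring of carbon only), on a carbonyl carbon and it has not yet been measured. Within the data shown here, no measured step shows what such a change does, and no step beyond the scatter is expected in this assay in either direction. The expected change is a number no higher from compound 1 to compound 3 (the limit leaves the size open) and would stay within the scatter. For compound 3 the estimate is 20000 nM with an expected range from 10000 nM to 40000 nM and a report of only a limit is likely.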

Compound 3, half-maximal cytotoxic concentration: > 20000 nM
Compound 3: a limit, no number (the forecaster's own chance of this, stated with the estimate: 85%); the middle value sits exactly at the limit.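

In this assay compound 3 gives > 20000 nM as a limit and not a number. Compound 1 gives > 20000 nM as a limit too. Among these compounds, no step between compound 1 and compound 3 can be read. The compounds shown leave open any actual number in this test, with all results at one limit: the limit of > 20000 nM in this assay, at which 3 of the 3 values shown sit.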